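From a fluorophenyl to a phenylethyl amine substituent

This account rests on a few compounds, and the source may have more. Where it says the series, first, only, none or still open, it means among the compounds named here.

Three measured compounds share one core. Compound 1 `CCCn1c(=O)[nH]c2nc(-c3ccc(S(=O)(=O)N4CCN(c5ccccc5Br)CC4)cc3)[nH]c2c1=O` carries a 2-bromophenyl group on the ring amine nitrogen, and in an assay on CHO cells for displacement of a labelled ligand from adenosine receptor A1 (Homo sapiens), read by scintillation counting, with a stated time of 90 min, in the presence of a further agent that is not named here (a higher number here means a weaker inhibitor, a lower number a stronger inhibitor), compound 1 gives only the limit > 1000 nM. Compound 2 `CCCn1c(=O)[nH]c2nc(-c3ccc(S(=O)(=O)N4CCN(c5ccccc5F)CC4)cc3)[nH]c2c1=O` differs by a fluoro in place of bromo on an aromatic carbon, and in this assay compound 2 likewise reaches only the limit > 1000 nM. Compound 3 `CCCn1c(=O)[nH]c2nc(-c3ccc(S(=O)(=O)N4CCN(c5cccc(F)c5)CC4)cc3)[nH]c2c1=O`, with 3-fluorophenyl on the same nitrogen, again gives in this assay only the limit > 1000 nM. The steps a step that the two limits leave unreadable from compound 1 to compound 2, a step that the two limits leave unreadable from compound 1 to compound 3 and a step that the two limits leave unreadable from compound 2 to compound 3 therefore cannot be sized, since every value sits at the limit of > 1000 nM in this assay, at which 3 of the 3 values shown sit. Compound 3 thus stands at the limit, no lower and no higher than any value shown.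

Compound 4 `CCCn1c(=O)[nH]c2nc(-c3ccc(S(=O)(=O)N4CCN(C(C)c5ccccc5)CC4)cc3)[nH]c2c1=O` changes the amine substituent: 1-phenylethyl in place of 3-fluorophenyl on an amine nitrogen in a ring. Going by the values given here, none of the three measured steps yields a size, so no measured step gives a number that bears on this change; the only guidance is that three aryl substituents on this nitrogen all stayed beyond the limit. The step that the limit leaves unreadable from compound 3 to compound 4 is expected to be small or again unreadable. Compound 4 is expected to give about 1500 nM in this assay, within 300 nM to 10000 nM, most likely reported once more only as a limit.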

Compound 4, inhibition constant: >= 1000 nM
Compound 4: no number, only a limit; the forecaster's own chance of this, stated with the estimate: 65%; the middle value is on the limit's open side.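

In this assay compound 4 gives >= 1000 nM as a limit and not a number. Going by these compounds alone, compound 1, compound 2 and compound 3 also give only limits, and no step from any of them to compound 4 can be read. The compounds shown leave open whether any substituent on this amine nitrogen gives a measurable inhibition constant.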